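Trimming the side chain of compound 2

The source may report more compounds than this note shows. Statements on the series, on what has been measured and on what is new or still open speak of the compounds shown alone.

Compound 1 `CC(C)(C)c1cc(-c2cc(=O)c3ccc(OCc4ccc5ccccc5n4)cc3o2)cc(C(C)(C)C)c1O` gives 3000 nM
Compound 2 `CC(C)(C)c1cc(-c2cc(=O)c3ccc(OCC(O)CO)cc3o2)cc(C(C)(C)C)c1O` gives 100 nM

In a functional assay for inhibition (on this read-out lower numbers stand for stronger inhibition and higher numbers for weaker inhibition), compound 2 holds the lower of the two numbers, at 100 nM. Compound 3 `COc1ccc2c(=O)cc(-c3cc(C(C)(C)C)c(O)c(C(C)(C)C)c3)oc2c1` differs from it by one change: hydrogen in place of 1,2-dihydroxyethyl on a saturated chain carbon bound to an oxygen on an aromatic ring, with hydrogen in place of 1,2-dihydroxyethyl. Within the data shown here, the only measured step at this chain carbon is large: a 30-fold lower number from compound 1 to compound 2 (1.48 log units; beyond the scatter). That step swaps one group for another and shows nothing about hydrogen there, so only a moderate rise, with wide uncertainty, is expected. The expected step is a 3.0-fold higher number from compound 2 to compound 3 (0.48 log units; beyond the scatter). For compound 3 the estimated value is 300 nM, within an expected range of 80 nM to 1500 nM.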

Compound 3, half-maximal inhibitory concentration: 1000 nM
For compound 3 the middle estimate is 3.3-fold (0.52 log units) below the measured one; measured number inside the range.
By their numbers in this assay, from the lowest: compound 2; then compound 3; then compound 1.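

Shortening 2,3-dihydroxypropoxy to methoxy gives a 10-fold higher number from compound 2 to compound 3 (1.00 log units; beyond the scatter) and shows that compound 2 owes its place to more than the loss of quinolin-2-yl. Hydrogen in place of quinolin-2-yl gives a 3.0-fold lower number from compound 1 to compound 3 (0.48 log units; beyond the scatter) as well. With methoxy as the reference, this position therefore moves the number both ways: 2,3-dihydroxypropyl goes with a lower one, and the quinolin-2-ylmethyl group goes with a higher one. From the compounds shown here alone, whether an amine, a carboxylic acid or a longer chain here would match 2,3-dihydroxypropyl remains open. Nothing shown explains either step.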